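This account rests on a few compounds, and the source may have more. Where it says the series, first, only, none or still open, it means among the compounds named here.

Measured so far:
Compound 1 `COc1ccc(CNc2nc([Se]C)nc3ccccc23)cc1` — in a functional assay on HT-29 cells (Homo sapiens) for cytotoxicity, read by MTT assay, with a stated time of 72 h (a lower number here means a stronger inhibitor of growth, a higher number a weaker inhibitor of growth), compound 1 gives > 100000 nM, a limit.
Compound 2 `CCCCC[Se]c1nc([Se]CCCCC)c2cccnc2n1` — in this assay compound 2 gives > 100000 nM, a limit.
Compound 3 `CSc1ccc(CNc2nc(SC)nc3ncccc23)cc1` — in this assay compound 3 gives 7030 nM.

Compound 1 stands at the limit of > 100000 nM in this assay, at which 2 of the 3 values shown sit; no number is known for it, only the limit. Compound 2 is at the same limit. For the measured compounds named here, compound 3 alone gives a number in this assay; no single-change step links compound 3 to compound 1, so the two values show only that one is a number and the other a limit.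

Compound 4 `COc1ccc(CNc2nc([SeH])nc3ccccc23)cc1` differs from compound 1 by hydrogen in place of methyl on a selenium. Going by the values given here, no measured pair shows this change, so no step size can be drawn from the series. The expectation is a step of no size beyond the scatter, in no particular direction, from compound 1 to compound 4, that is a number no higher from compound 1 to compound 4 (the limit leaves the size open) as an estimate. Compound 4 is therefore expected near 100000 nM, within 30000 nM to 300000 nM, and most likely to come back as a limit again.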

Compound 4, concentration for total growth inhibition: > 100000 nM
Compound 4: only a limit was reported (the forecaster's own chance of this, stated with the estimate: 70%); the middle value sits exactly at the limit.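

Compound 1 and compound 4 both stand only as limits in this assay, so hydrogen in place of methyl on a selenium gives no readable step: the limit of > 100000 nM in this assay, at which 3 of the 4 values shown sit.

The compounds shown leave open the size and direction of that change, and compound 3, the only one with a number, is linked to no other by a single change.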